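This account rests on a few compounds, and the source may have more. Where it says the series, first, only, none or still open, it means among the compounds named here.

Compound 1 `Oc1ccc(-c2cc(-c3ccccn3)nc(-c3ccccc3Cl)c2)cc1` — in a functional assay on HCT-15 cells (Homo sapiens) for cytotoxicity, read by CCK-8 assay and cell counting, with a stated time of 2 days (a lower number here means a stronger inhibitor, a higher number a weaker inhibitor), the entry reads "not determined" (no result reported).
Compound 2 `Oc1ccc(-c2cc(-c3ccco3)nc(-c3ccccc3Cl)c2)cc1` — 5460 nM.
Compound 3 `Oc1ccc(-c2cc(-c3cccc(Cl)c3)nc(-c3ccccn3)c2)cc1` — 28200 nM.

Among the two numbers that exist in this assay, compound 3 holds the higher one, and its distance from compound 2 lies beyond the scatter of repeated runs. Compound 4 `Oc1ccc(-c2cc(-c3cccc(Cl)c3)nc(-c3cccs3)c2)cc1` is the next step: thiophen-2-yl in place of pyridin-2-yl on an aromatic carbon. Among the measured compounds shown here, no measured pair shows this exchange, so the expected size of the step rests on nothing closer than the fact that compound 2, bearing a five-membered heteroaryl ring, gives 5460 nM. On that thin basis a modest move toward a lower number in this assay is expected, not one clearly beyond the scatter: a 2.0-fold lower number from compound 3 to compound 4 (0.30 log units; within the scatter). Compound 4 is thus estimated at 14000 nM, within 4000 nM to 45000 nM.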

Compound 4, half-maximal inhibitory concentration: 5050 nM
Compound 4: the middle estimate sits 2.8-fold (0.44 log units) above what was measured; low and high end bracket the measured number.
By their numbers in this assay, from the lowest: compounds 4 and 2 (each within the scatter of the next); then compound 3.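

In this assay, thiophen-2-yl in place of pyridin-2-yl, on the carbon next to the ring nitrogen, gives a 5.6-fold lower number from compound 3 to compound 4 (0.75 log units; beyond the scatter), the first measured change at a single place among these compounds. This position therefore responds to the exchange of a six-membered aromatic ring for a five-membered one, with the 3-chlorophenyl and 4-hydroxyphenyl groups unchanged. No measurement bearing on the reason for this step is available.

The compounds shown leave open whether the step follows the sulfur or the ring size. From the compounds shown here alone, how a thiazol-2-yl group or an amine would read at this carbon also remains open.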